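A few compounds are considered here, and "the series" means these few. Any claim that something is new, unique, unknown or untested is made for them only; others in the source may bear on it.

Among the measured compounds shown here, compound 1 `COc1ccnc(Nc2ccc(Cl)c(OCC=C(C)C)c2)n1` gives 9000 nM in an ADME assay on MT2 cells (Homo sapiens) for cytotoxicity (on this read-out higher numbers stand for lower toxicity in this test and lower numbers for higher toxicity in this test), the lowest of the two numbers measured so far. Compound 2 `COc1cc(N)nc(Nc2ccc(Cl)c(OCC=C(C)C)c2)n1` gives 19000 nM in this assay, and the step of a 2.1-fold higher number from compound 1 to compound 2 (0.32 log units; beyond the scatter) came with an amino in place of hydrogen on an aromatic carbon. Compound 3 `CCOc1ccnc(Nc2ccc(Cl)c(OCC=C(C)C)c2)n1` differs from compound 1 by methyl in place of hydrogen on a saturated chain carbon bound to an oxygen on an aromatic ring. For the measured compounds named here, no measured step involves this kind of change, so the single known step offers no guide, and no shift beyond the scatter is expected. Compound 3 is therefore estimated to give 9000 nM, between 4500 nM and 18000 nM. The expected step is then no change at the digits printed from compound 1 to compound 3 (within the scatter).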

Compound 3, half-maximal cytotoxic concentration: 19000 nM
Estimate against measurement, compound 3: 2.1-fold (0.32 log units) below; the measured number lies above the stated range.
By their numbers in this assay, from the lowest: compound 1; then compounds 2 and 3 (each within the scatter of the next).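

In this assay the change from methoxy to ethoxy gives a 2.1-fold higher number from compound 1 to compound 3 (0.32 log units; beyond the scatter) and so points toward lower toxicity in this test. Among the compounds shown here, this shows that the number responds to a single added methyl on a saturated chain carbon bound to an oxygen on an aromatic ring, a place the earlier compounds left unchanged. Nothing measured here accounts for the shift.

On these data alone, whether a longer chain, such as propoxy, or a branched one, such as isopropoxy, would carry the number further remains open. So does the effect of a hydroxyl group at the end of the ethoxy chain.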